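The compounds below may be only part of what the source reports. "The series", "measured", "known", "first", "only" and "open" are said of these compounds alone.

Measured so far:
compound 1, `CCC(C(=O)N1CCN(c2cccc(Cl)c2)CC1)N1C(=O)CCC1=O`: 0%
compound 2, `COc1cccc(N2CCN(C(=O)C(C)N3C(=O)CCC3=O)CC2)c1`: 0%
compound 3, `COCC(C(=O)N1CCN(c2cccc(C(F)(F)F)c2)CC1)N1C(=O)CCC1=O`: 50%

In a functional assay on the whole organism (strain Swiss) with Mus musculus as the target, in the maximal electroshock model, with a stated time of 1 h, at a dose of 100 mg/kg by the intraperitoneal route (a lower number here means a weaker effect, a higher number a stronger effect of the compound at the dose given), compound 1 gives 0%, and compound 2 gives 0%; the two stand level at the digits shown, and together they are the lowest of the three numbers. Compound 3 gives 50%, a reading that lies clearly higher than that of compound 1, with a gap beyond the usual scatter of this kind of measurement. Among the compounds with values here, no pair of these measured compounds differs in only one place, so no single structural change can yet be tied to a measured step.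

The next compound to be tested is compound 4, `CCC(C(=O)N1CCN(c2ccccc2)CC1)N1C(=O)CCC1=O`. It differs from compound 1 in one place: hydrogen in place of chloro on an aromatic carbon. Within the data shown here, nothing among the measured compounds shows what this change does on its own, so the expectation rests only on the low reading of compound 1 and on the fact that the shared core is kept. The step from compound 1 to compound 4 is expected to be small, either none beyond the scatter or a slight rise, giving an expected a number 10 percentage points higher from compound 1 to compound 4 (within the scatter). Compound 4 is therefore estimated at 10%, within a range from 0% to 40%.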

Compound 4, a percentage reported as activity, at one dose (the size of the read-out at that dose, not a potency): 0%
For compound 4 the middle estimate is 10 percentage points above the measured one, within the range that was stated.
By their numbers in this assay, from the lowest: compounds 1, 2 and 4 (each within the scatter of the next); then compound 3.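

Going from 3-chlorophenyl to phenyl gives, in this assay, no change at the digits printed from compound 1 to compound 4 (within the scatter), so taking chloro off this aromatic carbon and leaving hydrogen there does not lift the reading. Chloro at this position is therefore not what keeps compound 1 without a measurable effect at the dose given, since compound 4 lacks it and gives 0% as well. This is a single-dose read-out, and neither compound shows any effect. The pair cannot reveal whether chloro adds or removes anything here, and no measurement offered for this series bears on why the change leaves the reading where it stands.

On these data alone, whether a different group on this same aromatic carbon, such as a nitrile, a fluoro or an amine, would give a reading above that of compound 4 remains open while the rest of the core of compound 1 is kept. As far as these compounds go, the other compounds differ from this pair in more than one place, so their steps cannot be read, and the effect of a single change on any other part of the structure also remains unknown.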